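The source may hold more compounds than are shown below. What is called first, only, known or untested is meant among the compounds shown, and "the series" means these compounds.

Values so far in an ADME assay on Vero cells (Chlorocebus sabaeus) for cytotoxicity, read by resazurin assay, with a stated time of 24 h (a higher number here means that more compound is tolerated, a lower number that less compound is tolerated), are these
compound 1 `CC(=O)OC[C@H]1O[C@H](OC(C)C)C=CC1=O` gives 104000 nM
compound 2 `CCCCCCO[C@@H]1C=CC(=O)[C@@H](COC(=O)C(C)(C)C)O1` gives 4800 nM
compound 3 `CC(=O)OC[C@H]1O[C@H](OCCC(C)C)C=CC1=O` gives 19800 nM

Compound 2 has the lowest number of the three, so it is the least tolerated, and its gaps to compound 1 and compound 3 both lie beyond the usual scatter. The next compound, compound 4 `CC(C)CO[C@@H]1C=CC(=O)[C@@H](COC(=O)C(C)(C)C)O1` is compound 2 with a single change: isopropyl in place of pentyl on a saturated chain carbon bound to an oxygen on a saturated carbon which, cut one bond further out, reads hexyl to isobutyl.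

Among the compounds with values here, the one measured step that bears on this is a 5.3-fold lower number from compound 1 to compound 3 (0.72 log units; beyond the scatter) with isopentyl in place of isopropyl on an oxygen on a saturated carbon. That step is modest, and it enlarges the group, whereas the change to compound 4 reduces it. The comparison is only a loose guide, since compound 1 and compound 3 also differ from compound 2 elsewhere in their structure. Even so, the same kind of change run in reverse points to a higher number, of roughly the same size. The expected move is a 4.2-fold higher number from compound 2 to compound 4 (0.62 log units; beyond the scatter) and it would mean that more of compound 4 is tolerated. For compound 4 the estimated value is 20000 nM (expected range 8000 nM to 50000 nM).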

Compound 4, half-maximal cytotoxic concentration: 28200 nM
For compound 4 the middle estimate is 1.4-fold (0.15 log units) below the measured one; low and high end bracket the measured number.
By their numbers in this assay, from the lowest: compound 2; then compounds 3 and 4 (each within the scatter of the next); then compound 1.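

In this assay, going from hexyl to isobutyl on the oxygen gives a 5.9-fold higher number from compound 2 to compound 4 (0.77 log units; beyond the scatter) and so shows that this chain also matters when the rest of the molecule carries a different ester group. The earlier pair moved the other way, enlarging isopropyl to isopentyl with a 5.3-fold lower number from compound 1 to compound 3 (0.72 log units; beyond the scatter) as the result, so in both pairs the larger group goes with the lower number, meaning that less compound is tolerated, and neither pair goes against this. With only these two pairs, this is a shared trend and not a general rule, and no measurement is available to explain why the number moves with this chain.

The step from hexyl to isobutyl changes both the length and the branching of the chain, so the compounds shown cannot tell which of the two matters. A straight butyl chain would help to separate these two features, while a longer octyl chain or a chain carrying an amine would show whether the trend holds beyond the simple chains seen here.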